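The source may hold more compounds than are shown below. What is called first, only, known or untested is meant among the compounds shown, and "the series" means these compounds.

Measured compounds:
compound 1, `CCOC(=O)N1CCC(NS(=O)(=O)c2ccc(NCc3ccccc3)c3ccccc23)CC1`, 45.6 nM
compound 2, `CCOC(=O)N1CCC(NS(=O)(=O)c2ccc(NCCCc3ccccc3)c3ccccc23)CC1`, 32.1 nM
compound 3, `CCCNC(=O)N1CCC(NS(=O)(=O)c2ccc(NC(=O)c3ccccc3C)c3ccccc23)CC1`, 77.4 nM

All three were tested in an assay on L1.2 cells for binding affinity to C-C chemokine receptor type 8 (Homo sapiens); a lower number here means a stronger inhibitor, a higher number a weaker inhibitor. Compound 2 gives the lowest number of the three. Its nearest neighbour is compound 1, which lies within the scatter of it, so the two cannot be told apart; compound 3 sits further away, beyond the scatter, with the weaker value.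

The unmeasured compound 4, `CCOC(=O)N1CCC(NS(=O)(=O)c2ccc(N)c3ccccc23)CC1`, differs from compound 2 in one place: hydrogen in place of 3-phenylpropyl on a nitrogen on an aromatic ring. The whole 3-phenylpropyl chain with its aromatic ring is taken away and only a hydrogen is left on the nitrogen.

Within the data shown here, only one measured step touches this part of the molecule: a 1.4-fold lower number from compound 1 to compound 2 (0.15 log units; within the scatter). It shows that lengthening the chain between the nitrogen and the aromatic ring makes no difference beyond the scatter. Nothing measured shows what happens when the chain and ring are removed altogether. Among the measured compounds shown here, compound 3 carries a different group on that nitrogen and gives a weaker value, but no single-change step links it to compound 2.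

The entire aromatic appendage disappears, so a weaker binding is expected for compound 4, with wide uncertainty: the estimated value for compound 4 is 300 nM, in the range 60 nM to 1500 nM. This corresponds to an expected step of a 9.3-fold higher number from compound 2 to compound 4 (0.97 log units; beyond the scatter).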

Compound 4, inhibition constant: > 5000 nM
Compound 4: a limit, no number (the forecaster's own chance of this, stated with the estimate: 10%); middle value at least 16-fold (1.22 log units) away from the limit.
By their numbers in this assay, from the lowest: compounds 2, 1 and 3 (each within the scatter of the next, the first and the last beyond it). At a limit, above all of these: compound 4.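

In this assay compound 4 gives > 5000 nM, which is a limit of the assay and not a number. Replacing the group on the nitrogen with a hydrogen gives an at least 150-fold higher number from compound 2 to compound 4 (2.19 log units; beyond the scatter) for 3-phenylpropyl, and an at least 100-fold higher number from compound 1 to compound 4 (2.04 log units; beyond the scatter) for benzyl. The earlier pair showed only that benzyl and 3-phenylpropyl could not be told apart, whereas these steps show that, among compounds 1, 2 and 4, whether this nitrogen carries such a group at all matters far more than the length of the chain.

As far as these compounds go, how far the actual value of compound 4 lies past its limit stays unknown, so the full size of both steps is open. The compounds shown also cannot separate the part played by the aromatic ring from that of the chain carbons, and a plain butyl chain or a small methyl group on this nitrogen would be needed to tell how much of the appendage has to remain for binding to return.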